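A few compounds are considered here, and "the series" means these few. Any claim that something is new, unique, unknown or untested is made for them only; others in the source may bear on it.

Working notes on the series. In a physicochemical assay for solubility, read by HPLC, using the shake flask method, measured as kinetic solubility, with a stated time of 2 h, at pH 7.4 (on this read-out higher numbers stand for higher solubility and lower numbers for lower solubility), compound 1 `COc1ccc(-c2cnn3c(NCc4ccccn4)cc(C)nc23)cc1` gives only a limit, < 5000 nM. Compound 2 `Cc1cc(NCc2ccccn2)n2ncc(-c3cc(F)c(F)c(F)c3)c2n1` likewise gives a limit in this assay, < 5000 nM. For the measured compounds named here, the single measured step, a step that the two limits leave unreadable from compound 1 to compound 2, cannot be sized since (the limit of < 5000 nM in this assay, at which 2 of the 2 values shown sit). Compound 3 `Cc1cc(NCc2ccccn2)n2ncc(-c3cccc(N(C)C)c3)c2n1` differs from compound 2 by 3-(dimethylamino)phenyl in place of 3,4,5-trifluorophenyl on an aromatic carbon. No readable measured step bears on this change, so the numbers alone point to no direction beyond the scatter. Compound 3 is estimated at 4000 nM, between 800 nM and 20000 nM. The expected step is a step that the limit leaves unreadable from compound 2 to compound 3.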

Compound 3, solubility: 94600 nM
The estimate for compound 3 lay 24-fold (1.37 log units) below the measured number, and the stated range ends below it.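

At this aromatic carbon of the shared core, 3-(dimethylamino)phenyl gives an at least 18-fold higher number from compound 2 to compound 3 (1.27 log units; beyond the scatter) in this assay. Set against 4-methoxyphenyl, the same group gives an at least 18-fold higher number from compound 1 to compound 3 (1.27 log units; beyond the scatter). For the compounds shown here, these are the first readable steps, and they show that a change at this one place can move the number beyond the scatter.

The full size of both steps stays open, since compound 1 and compound 2 each give only a limit: the limit of < 5000 nM in this assay, at which 2 of the 3 values shown sit.

Also open, from the compounds shown here alone, is whether a primary amine, a morpholine or a carboxylic acid at this place would give a similar step.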